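Compound 2 to compound 4: one ring group exchanged

The compounds below may be only part of what the source reports. "The series", "measured", "known", "first", "only" and "open" are said of these compounds alone.

- Compound 1 `N#Cc1ccc(/C=C/S(=O)(=O)Cc2ccc(Nc3ncnc4ccccc34)cc2)cc1`: > 100000 nM, a limit
- Compound 2 `O=S(=O)(/C=C/c1ccc(Cl)c(Cl)c1)Cc1ccc(Nc2ncnc3ccccc23)cc1`: 22000 nM
- Compound 3 `CC(C)(C)c1cc(/C=C/S(=O)(=O)Cc2ccc(Nc3ncnc4ccccc34)cc2)cc(C(C)(C)C)c1O`: 3000 nM

In a functional assay on SK-OV-3 cells (Homo sapiens) (a higher number here means a weaker inhibitor of growth, a lower number a stronger inhibitor of growth), compound 2, at 22000 nM, has the higher of the two actual numbers, and compound 3 sits lower at 3000 nM. Compound 4 `O=S(=O)(/C=C/c1ccc(F)cc1Cl)Cc1ccc(Nc2ncnc3ccccc23)cc1`, not yet measured, carries 2-chloro-4-fluorophenyl in place of 3,4-dichlorophenyl (2-chloro-4-fluorophenyl in place of 3,4-dichlorophenyl on a double-bonded chain carbon bound to a double-bonded chain carbon). Among the compounds with values here, the one measured step at this place is an at least 4.5-fold lower number from compound 1 to compound 2 (0.65 log units; beyond the scatter). As far as these compounds go, that step starts from the limit of > 100000 nM in this assay, at which 1 of the 3 values shown sits, so its true size stays open. It replaced 4-cyanophenyl, whereas the new swap keeps a chlorine on the ring, so only a small shift is expected, probably none beyond the scatter. The expected change is a 1.4-fold lower number from compound 2 to compound 4 (0.14 log units; within the scatter). The estimated value for compound 4 is 16000 nM, within an expected range of 5000 nM to 50000 nM.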

Compound 4, concentration for 50% growth inhibition: 44000 nM
Compound 4: the middle estimate sits 2.8-fold (0.44 log units) below what was measured, within the range that was stated.
By their numbers in this assay, from the lowest: compound 3; then compounds 2 and 4 (each within the scatter of the next). At a limit, above all of these: compound 1.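

In this assay, exchanging 3,4-dichlorophenyl for 2-chloro-4-fluorophenyl gives a 2.0-fold higher number from compound 2 to compound 4 (0.30 log units; within the scatter), so these two chlorine-bearing rings cannot be told apart at this position. Set against 4-cyanophenyl, the new ring gives an at least 2.2-fold lower number from compound 1 to compound 4 (0.35 log units; beyond the scatter), so compound 4 joins compound 2 in lying beyond the scatter from compound 1. The true size of that step stays open because compound 1 stands at a limit: the limit of > 100000 nM in this assay, at which 1 of the 4 values shown sits.

Still open, as far as these compounds go, is how this ring would read carrying an amine or a carboxylic acid in place of its halogens.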